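The compounds below may be only part of what the source reports. "The series", "measured", "known", "first", "only" and "open" are said of these compounds alone.

Compound 1 `CC(C)(C)Sc1c(CC(C)(C)C(=O)O)n(Cc2ccc(Cl)cc2)c2ccc(OCc3ccc4cc(F)c(F)cc4n3)cc12`: 7 nM. Compound 2 `CC(C)(C)Sc1c(CC(C)(C)C(=O)O)n(Cc2ccc(Cl)cc2)c2ccc(OCc3nc4cc(C(F)(F)F)ccc4s3)cc12`: 22 nM.

In a functional assay for inhibition, with Homo sapiens as the target (on this read-out higher numbers stand for weaker inhibition and lower numbers for stronger inhibition), compound 1 gives 7 nM, the lowest of the two numbers; compound 2 gives 22 nM, a gap beyond the usual scatter. Compound 3 `CC(C)(C)Sc1c(CC(C)(C)C(=O)O)n(Cc2ccc(Cl)cc2)c2ccc(OCc3nc4ccccc4o3)cc12` has not been measured. It differs from compound 1 in one place: a group of 9 heavy atoms (7 carbon, 1 nitrogen, 1 oxygen; one five-membered aromatic ring with 2 hetero atoms, one six-membered aromatic ring of carbon only) in place of a group of 12 heavy atoms (9 carbon, 1 nitrogen, 2 fluorine; one six-membered aromatic ring of carbon only, one six-membered aromatic ring with 1 hetero atom), on a saturated chain carbon bound to an oxygen on an aromatic ring. For the measured compounds named here, no measured pair shows this exact change, so its size is uncertain; a moderate weakening is expected because compound 2 with 22 nM sits weaker than compound 1 after a change of the same kind. The expected step is a 3.6-fold higher number from compound 1 to compound 3 (0.55 log units; beyond the scatter). Compound 3 is estimated at 25 nM, within 8 nM to 80 nM.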

Compound 3, half-maximal inhibitory concentration: < 7 nM
Compound 3 gave a limit, no number; the forecaster's own chance of this, stated with the estimate: 3%; middle value at least 3.5-fold (0.55 log units) away from the limit.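

Putting 1,3-benzoxazol-2-yl in place of the group of compound 1, on a saturated chain carbon bound to an oxygen on an aromatic ring, gives a number no higher from compound 1 to compound 3 (the limit leaves the size open) in this assay. This place therefore accepts a group of 9 heavy atoms with a five-membered aromatic ring with 2 hetero atoms, with no loss of inhibition. How large the step is cannot be read: the limit of < 7 nM in this assay, at which 1 of the 3 values shown sits.

As far as these compounds go, whether an amine or a lone oxazole ring at this place would also keep inhibition stays open. From the compounds shown here alone, how far compound 3 lies from compound 1 also stays open.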